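A few compounds are considered here, and "the series" means these few. Any claim that something is new, unique, unknown or untested is made for them only; others in the source may bear on it.

Measured compounds:
- compound 1 `O=C1c2ccc(OCc3cccc(-c4ccc(Cl)cc4F)c3)cc2CN1C1CCCC1` — in an ADME assay on a cell-free system (plasma, Rattus norvegicus) for metabolic stability, read by LC-MS, with a stated time of 1 h, at 37 degrees C, tested at 100 uM (on this read-out higher numbers stand for a more stable compound and lower numbers for a less stable compound), compound 1 gives "not determined" (no result reported)
- compound 2 `O=C(O)c1ccc(Cl)c(-c2cccc(COc3ccc4c(c3)CN(C3CCCC3)C4=O)c2)c1` — compound 2 gives 100%
- compound 3 `COc1ccc(-c2cccc(COc3ccc4c(c3)CN(C3CCCC3)C4=O)c2)cc1C(=O)O` — compound 3 gives 100%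

Compound 1 therefore stands nowhere on the numbers: there is no single value for compound 1 in this assay, only the two readings of its relatives.

The step under consideration goes from compound 1 to compound 4 `O=C(O)c1cc(F)cc(-c2cccc(COc3ccc4c(c3)CN(C3CCCC3)C4=O)c2)c1`, with the change (3-carboxy-5-fluorophenyl in place of 4-chloro-2-fluorophenyl on an aromatic carbon). Going by the values given here, both measured compounds carry a carboxy-bearing phenyl at the same position of the shared core, and the only measured step, no change at the digits printed from compound 2 to compound 3 (within the scatter), shows that exchanging one carboxy-bearing phenyl for another left the read-out unchanged. Compound 4 is a third compound of this kind. On that basis no step beyond the scatter is expected between the carboxylic acids, and compound 4 is expected to behave like compound 2 and compound 3. The value of compound 4 in this assay is estimated at 98%, with a range from 85% to 100%. Among the compounds with values here, no measured step gives a number for the change from compound 1 itself.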

Compound 4, percent of the compound remaining: 95%
For compound 4 the middle estimate is 3 percentage points above the measured one; the range from low to high includes it.
By their numbers in this assay, from the lowest: compounds 4, 2 and 3 (each within the scatter of the next).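

In this assay, the 3-carboxy-5-fluorophenyl group gives a number 5 percentage points lower from compound 3 to compound 4 (within the scatter) and a number 5 percentage points lower from compound 2 to compound 4 (within the scatter), so a third carboxy-bearing phenyl on this aromatic carbon stays level with the first two. The fluorine of compound 4 thus joins the chlorine of compound 2 and the methoxy of compound 3 as a substituent on the carboxy-bearing phenyl, with no step beyond the scatter among these three compounds.

Going by these compounds, compound 1 has no number in this assay, so the change from 4-chloro-2-fluorophenyl to 3-carboxy-5-fluorophenyl cannot be read, and the part played by the carboxylic acid itself stays open. Also open, on these data alone, is whether a phenyl carrying an amine or a primary amide in place of the carboxy group would read the same. No measurement at hand accounts for the level read-out across compounds 2, 3 and 4.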